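The compounds below may be only part of what the source reports. "The series", "measured", "known", "first", "only" and "open" are said of these compounds alone.

Compound 2 `COc1ccc(CNC(=O)/C(C#N)=C/c2ccco2)cc1` was tested in a functional assay on MCF7 cells (Homo sapiens) for inhibition, read by MTT assay, with a stated time of 72 h (a higher number here means a weaker inhibitor of growth, a lower number a stronger inhibitor of growth), where compound 2 gives 27000 nM. For the measured compounds named here, of the two numbers measured so far, this is the highest, meaning the weakest growth inhibition. The nearest neighbour is compound 1 `N#C/C(=C\c1ccc[nH]1)C(=O)NCc1ccc(Cl)c(Cl)c1`, which in this assay gives 6000 nM; the gap between the two lies beyond the usual scatter of repeated measurements, so compound 1 is the stronger growth inhibitor of the pair. Compound 3 `COc1ccc(CNC(=O)/C(C#N)=C/c2ccc(Cl)cc2)cc1` has not yet been measured. It differs from compound 2 in one place: 4-chlorophenyl in place of furan-2-yl on a double-bonded chain carbon bound to a double-bonded chain carbon. Going by the values given here, no measured pair in this set differs by that same change, so there is no direct guide to the size of the step it brings. With compound 2 as the only anchor, the expectation is a modest shift towards stronger growth inhibition, not clearly beyond the scatter. The step expected here is a 1.8-fold lower number from compound 2 to compound 3 (0.26 log units; within the scatter) in this assay. Compound 3 is expected to give about 15000 nM in this assay, within a range from 4000 nM to 50000 nM.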

Compound 3, concentration for 50% growth inhibition: 11000 nM
The estimate for compound 3 lay 1.4-fold (0.13 log units) above the measured number; measured number inside the range.
By their numbers in this assay, from the lowest: compounds 1 and 3 (each within the scatter of the next); then compound 2.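

In this assay, replacing furan-2-yl with 4-chlorophenyl on a double-bonded chain carbon bound to a double-bonded chain carbon gives a 2.5-fold lower number from compound 2 to compound 3 (0.39 log units; beyond the scatter), a modest step but one beyond the scatter. For the compounds shown here, this is the first direct reading at this position: with the rest of the molecule unchanged, the ring attached there affects growth inhibition, and the swap to a six-membered aromatic ring of carbon only, carrying chlorine, strengthens it rather than weakening it. Nothing available explains this step, so its cause remains unknown.

This single swap changes the ring size, removes the ring oxygen and adds the chlorine all at once, so the compounds shown cannot tell which of these changes matters; a plain phenyl group at this position would separate the effect of the chlorine from that of the ring, and an amine or a carboxylic acid in place of the chlorine would test a very different kind of group. Going by these compounds, it also remains open whether the same swap gives a similar step when the rest of the molecule differs.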